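The compounds below may be only part of what the source reports. "The series", "measured", "known", "first", "only" and "open" are said of these compounds alone.

Compound 1 `CCC(C)(C)Cc1c[nH]c(CCc2ccc(-c3ccncc3)cc2)n1` was tested in a functional assay on HEK293 cells for agonist activity at Bombesin receptor subtype-3 (Homo sapiens), read by luminescence and calcium flux, with a stated time of 10 min (a lower number here means that less compound is needed, a higher number that more compound is needed for the effect), where compound 1 gives 305 nM. Among the three measured compounds it holds the second highest number: compound 2 `CCC(C)(C)Cc1c[nH]c(CCc2ccc(-n3ncnn3)cc2)n1` gives 422 nM, a step of a 1.4-fold higher number from compound 1 to compound 2 (0.14 log units; within the scatter), while compound 3 `CCC(C)(C)Cc1c[nH]c(CCc2ccc(-c3cnsc3)cc2)n1` gives 44 nM, a step of a 6.9-fold lower number from compound 1 to compound 3 (0.84 log units; beyond the scatter). Compound 4 `CCC(C)(C)Cc1c[nH]c(CCc2ccc(-n3cccn3)cc2)n1` differs from compound 1 in one place: 1H-pyrazol-1-yl in place of pyridin-4-yl on an aromatic carbon. Both measured steps bear on this change, since each also swaps pyridin-4-yl for a five-membered aromatic ring; the 2H-tetrazol-2-yl of compound 2 stayed within the scatter, whereas the 1,2-thiazol-4-yl of compound 3 gave a modest lowering. The incoming 1H-pyrazol-1-yl is closer in kind to 2H-tetrazol-2-yl, so a step of about a 1.2-fold lower number from compound 1 to compound 4 (0.07 log units; within the scatter) is expected, within the scatter. Compound 4 is therefore estimated at 260 nM, with a likely range of 80 nM to 800 nM.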

Compound 4, half-maximal effective concentration: 135 nM
Compound 4: middle estimate off by 1.9-fold (0.28 log units), on the high side; the measured number falls inside the stated range.
By their numbers in this assay, from the lowest: compound 3; then compound 4; then compounds 1 and 2 (each within the scatter of the next).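

Placing 1H-pyrazol-1-yl on this aromatic carbon gives a 2.3-fold lower number from compound 1 to compound 4 (0.35 log units; beyond the scatter) and so shows that a five-membered ring can lower the number here without sulfur in the ring. It also separates two rings joined through nitrogen, since changing the ring gives a 3.1-fold lower number from compound 2 to compound 4 (0.49 log units; beyond the scatter) in this series. The 1,2-thiazol-4-yl group still needs less compound, with a 3.1-fold higher number from compound 3 to compound 4 (0.49 log units; beyond the scatter) for the change, so ring size alone does not set the number. On these data alone, how a morpholine or a carboxylic acid would fare at this position stays open. No evidence here explains these differences.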